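The source may report more compounds than this note shows. Statements on the series, on what has been measured and on what is new or still open speak of the compounds shown alone.

Compound 1 `COc1ccc(C(=O)/C=C/c2ccc(N(C)C)cc2)c2c1C=CC(C)(C)O2` gives 730 nM
Compound 2 `COc1ccc(C(=O)/C=C/c2ccc(Cl)cc2)c2c1C=CC(C)(C)O2` gives > 10000 nM

Both compounds were tested in a functional assay on HepG2 cells (Homo sapiens) for antiproliferative activity, read by MTT assay, with a stated time of 24 h; a lower number here means a stronger inhibitor, a higher number a weaker inhibitor. There, compound 1 gives a true number, 730 nM, while compound 2 does not. Compound 2 gives > 10000 nM, which is a limit of the assay and not a number. It therefore stands at the limit of > 10000 nM in this assay, at which 1 of the 2 values shown sits, with no exact place on the scale.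

The next compound is compound 3 `COc1ccc(C(=O)/C=C/c2cccc(Cl)c2)c2c1C=CC(C)(C)O2`, which has the same atoms as compound 2, joined differently: 3-chlorophenyl in place of 4-chlorophenyl on a double-bonded chain carbon bound to a double-bonded chain carbon.

For the measured compounds named here, only one measured step bears on this change, and only indirectly. It is large, an at least 13-fold higher number from compound 1 to compound 2 (1.13 log units; beyond the scatter), but it swaps one group for another and does not shift the chloro. Compound 3 keeps the chloro, the group found on the weak side of that step, and it has no dimethylamino. No step beyond the scatter is therefore expected in this assay, and a limit may well be reported again. The expected change is a number no higher from compound 2 to compound 3 (the limit leaves the size open). For compound 3 the estimated value is 10000 nM, with an expected range from 3000 nM to 30000 nM.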

Compound 3, half-maximal inhibitory concentration: > 10000 nM
Compound 3 ended at the assay's limit; the forecaster's own chance of this, stated with the estimate: 70%; the middle value lies on the limit itself.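

Moving the chloro leaves the result in this assay unchanged in kind: compound 3 gives > 10000 nM, which is a limit of the assay and not a number. The effect of the move itself cannot be read, because compound 2 and compound 3 sit at the same limit, so neither chloro placement can be ranked over the other: the limit of > 10000 nM in this assay, at which 2 of the 3 values shown sit.

What compound 3 adds is a second comparison with compound 1: replacing 4-(dimethylamino)phenyl with 3-chlorophenyl gives an at least 13-fold higher number from compound 1 to compound 3 (1.13 log units; beyond the scatter), so the large loss first seen with 4-chlorophenyl is not tied to that one placement of the chloro.

The compounds shown leave open how much activity, if any, compound 2 and compound 3 have beyond the limit, and whether the dimethylamino group would keep its value if it sat where the chloro sits in 3-chlorophenyl. They also leave open whether the activity of compound 1 needs dimethylamino specifically, or whether another amine, such as a pyrrolidine or a morpholine, or a smaller group such as a hydroxyl, would serve in its place.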